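Replacing the Acetylpiperidinyl Amide with a Methyl Lactam

The source may hold more compounds than are shown below. What is called first, only, known or untested is meant among the compounds shown, and "the series" means these compounds.

Compound 1 `CN(C)C(=O)c1ccncc1Nc1cc(-c2ccc3ccn(C)c3c2)c2nccnc2c1` gives, in an assay on lysate for inhibition of 6-phosphofructo-2-kinase/fructose-2,6-bisphosphatase 3 (Homo sapiens), with stated times of 0.5 min and 45 min (on this read-out lower numbers stand for stronger inhibition and higher numbers for weaker inhibition), a value that is a limit of the assay: > 100000 nM.
Compound 2 `Cn1cc(NC(=O)c2ccncc2Nc2cc(-c3ccc4ccn(C)c4c3)c3nccnc3c2)cn1` gives in this assay 26500 nM.
Compound 3 `CC(=O)N1CCC(NC(=O)c2ccncc2Nc2cc(-c3ccc4ccn(C)c4c3)c3nccnc3c2)CC1` gives in this assay 31300 nM.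

Compound 3 stands at the highest of the two numbers shown; its nearest neighbour is compound 2, with a 1.2-fold higher number from compound 2 to compound 3 (0.07 log units; within the scatter). The value of compound 1 is only a limit (the limit of > 100000 nM in this assay, at which 1 of the 3 values shown sits). Compound 4 `CN1CC(NC(=O)c2ccncc2Nc2cc(-c3ccc4ccn(C)c4c3)c3nccnc3c2)CCC1=O` differs from compound 3 by 1-methyl-6-oxopiperidin-3-yl in place of 1-acetylpiperidin-4-yl on an amide-type nitrogen. Among the compounds with values here, the steps that bear on this are an at least 3.1-fold lower number from compound 1 to compound 3 (0.50 log units; beyond the scatter), an at least 3.7-fold lower number from compound 1 to compound 2 (0.57 log units; beyond the scatter) and a 1.2-fold higher number from compound 2 to compound 3 (0.07 log units; within the scatter): exchanging one ring amine on the amide nitrogen for another changed little, while only the dimethylamino amide stood apart. For compound 4 no step beyond the scatter is therefore expected, a 1.0-fold lower number from compound 3 to compound 4 (0.02 log units; within the scatter), and its value in this assay is estimated at 30000 nM, within 12000 nM to 80000 nM.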

Compound 4, half-maximal inhibitory concentration: 96500 nM
Estimate against measurement, compound 4: 3.2-fold (0.51 log units) below; the whole stated range lies below it.
By their numbers in this assay, from the lowest: compounds 2 and 3 (each within the scatter of the next); then compound 4. At a limit, above all of these: compound 1.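

Compound 2 and compound 3 suggested that the ring on the amide-type nitrogen could be exchanged freely, but this change shows otherwise in this assay: a 3.1-fold higher number from compound 3 to compound 4 (0.49 log units; beyond the scatter) and a 3.6-fold higher number from compound 2 to compound 4 (0.56 log units; beyond the scatter). Even two six-membered non-aromatic rings with one hetero atom each, and with matching donor and acceptor counts, are thus not interchangeable here. The remaining step is an at least 1.0-fold lower number from compound 1 to compound 4 (0.01 log units; that floor lies within the scatter). The value of compound 1 is a limit: the limit of > 100000 nM in this assay, at which 1 of the 4 values shown sits.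

Open, from the compounds shown here alone, is whether the methyl on the lactam nitrogen matters, which the unmethylated lactam would test, and how a plain cyclohexyl ring would compare.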